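Series notes: removing a chain methyl from compound 1

The source may hold more compounds than are shown below. What is called first, only, known or untested is meant among the compounds shown, and "the series" means these compounds.

Compound 1 `CCC(C)C1NC(=O)N(C2CCCCC2)C1=O` stands only at a limit: in a functional assay on CCRF-CEM cells (Homo sapiens) for inhibition (a higher number here means a weaker inhibitor, a lower number a stronger inhibitor), compound 1 gives > 200000 nM, which is a limit of the assay and not a number. Compound 2 `CC(C)C(NC(=O)NO)C(=O)NC1CCCC1` likewise stops at a limit, giving > 200000 nM in this assay. Both values sit at the limit of > 200000 nM in this assay, at which 2 of the 2 values shown sit. Compound 3 `CC(C)C1NC(=O)N(C2CCCCC2)C1=O` differs by hydrogen in place of methyl on a saturated chain carbon, two bonds along the chain from a saturated ring carbon. Going by the values given here, with no measured step available, no shift beyond the scatter is expected; the estimated step is a step that the limit leaves unreadable from compound 1 to compound 3. Compound 3 is expected at 250000 nM, range 100000 nM to 600000 nM, most likely reported again only as a limit.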

Compound 3, half-maximal inhibitory concentration: > 200000 nM
Compound 3 ended at the assay's limit; the forecaster's own chance of this, stated with the estimate: 85%; the middle value does not contradict the limit.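

Compound 1 and compound 3 both stop at a limit of the assay, so no step between them can be read: the limit of > 200000 nM in this assay, at which 3 of the 3 values shown sit.

The compounds shown leave open what change to the shared core, if any, would bring a measurable value in this assay.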